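Adding a Second Fluorine to a Potent Urea

A few compounds are considered here, and "the series" means these few. Any claim that something is new, unique, unknown or untested is made for them only; others in the source may bear on it.

In a functional assay for antagonist activity at melanin-concentrating hormone receptor 1 (Homo sapiens) (on this read-out lower numbers stand for stronger inhibition and higher numbers for weaker inhibition), compound 1 `N#Cc1cccc([C@]23CCC(N(CCN4CC[C@@H](O)C4)C(=O)Nc4ccccc4)CC2C3)c1` gives 132 nM. For the measured compounds named here, compound 2 `CC(C)N(CCN(C(=O)Nc1cccc(F)c1)C1CC[C@]2(c3cccc(C#N)c3)CC2C1)C(C)C` gives 2.1 nM in this assay and stands lowest of the two numbers known so far; compound 1 sits well beyond the scatter above it. Compound 3 `CC(C)N(CCN(C(=O)Nc1ccc(F)c(F)c1)C1CC[C@]2(c3cccc(C#N)c3)CC2C1)C(C)C` has not yet been measured. It differs from compound 2 in one place: fluoro in place of hydrogen on an aromatic carbon. Going by the values given here, no measured pair shows this same change, so nothing beyond the numbers for compound 1 and compound 2 can guide the expectation. A single fluorine added on the aromatic ring is expected to move the read-out only a little, in either direction, and not beyond the usual scatter. Compound 3 is therefore estimated at 2.5 nM, with a range from 1 nM to 7 nM. The step of a 1.2-fold higher number from compound 2 to compound 3 (0.08 log units; within the scatter) that this estimate implies is expected to be small.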

Compound 3, inhibition constant: 2.8 nM
Estimate against measurement, compound 3: 1.1-fold (0.05 log units) below; measured number inside the range.
By their numbers in this assay, from the lowest: compounds 2 and 3 (each within the scatter of the next); then compound 1.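

In this assay, the change from 3-fluorophenyl to 3,4-difluorophenyl comes out as a 1.3-fold higher number from compound 2 to compound 3 (0.12 log units; within the scatter), so the two compounds cannot be told apart on this read-out. For the compounds shown here, no earlier pair carried this change, and it now shows that this aromatic carbon, ortho to a fluoro group and para to a large group, takes fluoro in place of hydrogen with no step beyond the scatter. The compounds shown offer no measurement that would explain this result.

On these data alone, whether a larger group at this carbon, such as chlorine, methoxy or an amine, would be accepted as fluoro is remains open. Also open, as far as these compounds go, is whether the same fluoro change would give so small a step with the hydroxypyrrolidine-bearing chain of compound 1 in place of the chain of compound 2.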